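The compounds below may be only part of what the source reports. "The series", "measured", "known", "first", "only" and "open" are said of these compounds alone.

Working notes on the series.

Within the data shown here, in a functional assay on cells (Lymphocyte, Homo sapiens) (a higher number here means a weaker inhibitor, a lower number a stronger inhibitor), compound 1 `Cc1cccc(NC(=O)N2CCN(c3nc(N)nc4sc(-c5ccc(F)cc5)nc34)CC2)c1` gives 300 nM and stands lowest of the three numbers so far. Compound 2 `Nc1nc(N2CCN(C(=O)COc3ccc(Cl)cc3)CC2)c2nc(CCc3ccc(F)cc3)sc2n1` gives 4400 nM in this assay and compound 3 `Nc1nc(N2CCN(C(=O)COc3ccc(Cl)cc3)CC2)c2nc(CCOc3ccc(F)cc3)sc2n1` gives 3540 nM; the step of a 1.2-fold lower number from compound 2 to compound 3 (0.09 log units; within the scatter) concerns the thiazole substituent and does not touch the carbonyl. Compound 4 `Nc1nc(N2CCN(C(=O)COc3ccccc3)CC2)c2nc(-c3ccc(F)cc3)sc2n1` differs from compound 1 at the carbonyl: phenoxymethyl in place of (3-methylphenyl)amino on a carbonyl carbon. Among the measured compounds shown here, no measured step isolates this change. Compounds 2 and 3 carry a related phenoxymethyl carbonyl together with other changes and both sit well above compound 1, so a move to a higher number is expected, of uncertain size. Compound 4 is therefore estimated at 1500 nM in this assay, between 450 nM and 5000 nM, an expected step of a 5.0-fold higher number from compound 1 to compound 4 (0.70 log units; beyond the scatter).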

Compound 4, half-maximal inhibitory concentration: 90 nM
Compound 4: middle estimate off by 17-fold (1.22 log units), on the high side; the whole stated range lies above it.
By their numbers in this assay, from the lowest: compound 4; then compound 1; then compounds 3 and 2 (each within the scatter of the next).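

At this carbonyl carbon, the hydrogen-bond donor of (3-methylphenyl)amino is not required for a low number in this assay: phenoxymethyl in its place gives a 3.3-fold lower number from compound 1 to compound 4 (0.52 log units; beyond the scatter), a modest step beyond the scatter. The change is a single swap on the shared core, so it shows this position directly, but it replaces the linking atom and removes the ring methyl together. No available evidence accounts for the step.

Which of these two differences carries the step remains open. Also open, as far as these compounds go, is how a 3-methylphenoxymethyl group, or a longer chain between carbonyl and ring, would read here.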